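Methyl on the aromatic ring across two cores

A few compounds are considered here, and "the series" means these few. Any claim that something is new, unique, unknown or untested is made for them only; others in the source may bear on it.

Compound 1 `COC(=O)[C@@]1(C)CCC=C2[C@@H]1CC[C@@H](C)[C@]2(C)Cc1c(C)[nH]c2ccccc12` and compound 2 `COC(=O)[C@@]1(C)CCC=C2[C@@H]1CC[C@@H](C)[C@]2(C)Cc1c(C)[nH]c2c(C)cccc12` share a core. In a functional assay on HBL-100 cells (Homo sapiens) for inhibition, read by sulforhodamine B assay, with a stated time of 48 h (a higher number here means a weaker inhibitor of growth, a lower number a stronger inhibitor of growth), compound 1 gives 14000 nM and compound 2 gives 16000 nM; the change methyl in place of hydrogen on an aromatic carbon made a 1.1-fold higher number from compound 1 to compound 2 (0.06 log units; within the scatter). Compound 3 `COC(=O)[C@@]1(C)CC[C@@H]2C3=C1CC[C@@H](C)[C@]3(C)Cc1c2[nH]c2ccccc12` rests on a core whose difference from the core of compound 1 is not broken down here. In this assay compound 3 gives 3500 nM, the lowest of the three numbers. Compound 4 `COC(=O)[C@@]1(C)CC[C@@H]2C3=C1CC[C@@H](C)[C@]3(C)Cc1c2[nH]c2ccc(C)cc12` differs from compound 3 by methyl in place of hydrogen on an aromatic carbon, the same kind of change as from compound 1 to compound 2, though not the same: there the ring is part of a fused or bridged system of two rings, ortho to a fused ring and meta to a fused ring; here it is part of a fused or bridged system of five rings, meta to a fused ring and para to a fused ring. For compound 4 the expected step in this assay is a 1.1-fold higher number from compound 3 to compound 4 (0.06 log units; within the scatter), because a 1.1-fold higher number from compound 1 to compound 2 (0.06 log units; within the scatter) lay within the scatter. Compound 4 is therefore estimated at 4000 nM, with a likely range from 1800 nM to 9000 nM.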

Compound 4, concentration for 50% growth inhibition: 11000 nM
Compound 4: the middle estimate sits 2.8-fold (0.44 log units) below what was measured, and the stated range ends below it.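

In this assay methyl in place of hydrogen on an aromatic carbon makes a 3.1-fold higher number from compound 3 to compound 4 (0.50 log units; beyond the scatter) and this step does not match the one on the other core: the same change on two cores in this assay, a 1.1-fold higher number (0.06 log units; within the scatter) from compound 1 to compound 2 and a 3.1-fold higher number (0.50 log units; beyond the scatter) from compound 3 to compound 4, 2.8-fold (0.44 log units) apart, beyond the scatter of two such steps

So the size of this change did not carry from the core of compound 1 to the core of compound 3. It cannot be assigned to the core alone, since the methyl of compound 4 also sits at a different place on the ring, meta to a fused ring and para to a fused ring. Two pairs give no rule for the series.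

Open, as far as these compounds go, is how methyl would behave at the place it holds in compound 2 on the core of compound 3, and at the place it holds in compound 4 on the core of compound 1. Also open, from the compounds shown here alone, is how other groups on this ring, such as methoxy, an amine or a carboxylic acid, would compare.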